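Swapping isopropyl for methyl on a weak inhibitor

The source may hold more compounds than are shown below. What is called first, only, known or untested is meant among the compounds shown, and "the series" means these compounds.

Measured compounds:
compound 1, `Cc1ccc(Nc2nc(SCc3cn(CC(=O)NC(=O)Nc4ccccn4)nn3)nc(-c3ccc(C(C)C)cc3)c2C#N)cc1`: 3360 nM
compound 2, `COc1cc(-c2nc(SCc3cn(CC(=O)NC(=O)Nc4ccccn4)nn3)nc(Nc3ccc(C(C)C)cc3)c2C#N)cc(OC)c1OC`: 35500 nM

Both compounds were tested in a functional assay on MGC-803 cells (Homo sapiens) for inhibition, read by MTT assay, with a stated time of 72 h; a lower number here means a stronger inhibitor, a higher number a weaker inhibitor. Compound 1 gives 3360 nM, while compound 2 gives 35500 nM and so stands as the higher of the two numbers, the gap to compound 1 being beyond the scatter. The two structures differ in more than one place, so their values are only compared, not traced to a single change.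

Compound 3, `COc1cc(-c2nc(SCc3cn(CC(=O)NC(=O)Nc4ccccn4)nn3)nc(Nc3ccc(C)cc3)c2C#N)cc(OC)c1OC`, has not yet been measured. Among the compounds with values here, its only difference from compound 2 is methyl in place of isopropyl on an aromatic carbon, on an aromatic carbon of a six-membered aromatic ring of carbon only, para to a large group. Within the data shown here, no measured pair shows this change alone, so the step is expected to be modest, perhaps toward a somewhat lower number, and may well stay within the scatter. The estimate for compound 3 is 25000 nM, spanning 8000 nM to 80000 nM, an expected step of a 1.4-fold lower number from compound 2 to compound 3 (0.15 log units; within the scatter).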

Compound 3, half-maximal inhibitory concentration: 7030 nM
Beside the measured number, compound 3's estimate is 3.6-fold (0.55 log units) above it; measured number outside the range, below it.
By their numbers in this assay, from the lowest: compound 1; then compound 3; then compound 2.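

In this assay, the change from (4-isopropylphenyl)amino to (4-methylphenyl)amino gives a 5.0-fold lower number from compound 2 to compound 3 (0.70 log units; beyond the scatter), so this small edit, which removes only two carbons, is enough to shift the result beyond the scatter. With the (4-methylphenyl)amino group held constant, the other aromatic group also matters: 3,4,5-trimethoxyphenyl in place of 4-isopropylphenyl gives a 2.1-fold higher number from compound 1 to compound 3 (0.32 log units; beyond the scatter), again beyond the scatter. Nothing available explains why either change alters the number.

The compounds shown do not reveal whether an amine, a hydroxyl group or a longer chain in place of the methyl would lower the number further. They also leave open whether the same isopropyl-to-methyl step would have a similar effect with a different group on the rest of the core.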